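Notes on the 2,4-difluorophenyl step to compound 4

The source may hold more compounds than are shown below. What is called first, only, known or untested is meant among the compounds shown, and "the series" means these compounds.

Of the compounds shown here, three have been measured in a functional assay on MCF7 cells (Homo sapiens) for antiproliferative activity; on this read-out higher numbers stand for weaker inhibition and lower numbers for stronger inhibition. Compound 1 `Cc1c(O)ccc2cc(-n3cc(-c4ccccc4)nn3)c(=O)oc12` gives 25200 nM. Compound 2 `CC(=O)Oc1ccc2cc(-n3cc(-c4ccccc4)nn3)c(=O)oc2c1C` gives 40800 nM. Compound 3 `CO[C@@H]1[C@@H](O)[C@@H](O)[C@H](Oc2ccc3c(c2C)OC(=O)C(n2cc(-c4ccc(C)cc4)nn2)C3)OC1(C)C` returns only a limit, > 100000 nM, and not a number. Among the numbers shown, compound 2 has compound 1 as its nearest neighbour; the step of a 1.6-fold higher number from compound 1 to compound 2 (0.21 log units; within the scatter) is within the scatter, so the two cannot be told apart on this read-out. The third value shown is the limit of > 100000 nM in this assay, at which 1 of the 3 values shown sits.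

Compound 4 `CC(=O)Oc1ccc2cc(-n3cc(-c4ccc(F)cc4F)nn3)c(=O)oc2c1C` differs from compound 2 in one place: 2,4-difluorophenyl in place of phenyl on an aromatic carbon. Among the compounds with values here, no measured step touches this part of the molecule. Within the data shown here, the only measured step, acetyl in place of hydrogen on an oxygen on an aromatic ring, was a 1.6-fold higher number from compound 1 to compound 2 (0.21 log units; within the scatter) and sits elsewhere in the structure; it gives no guidance on the aromatic ring attached to the five-membered ring. There is therefore no basis in the measured series for a step of any size or direction on replacing phenyl by 2,4-difluorophenyl, and the expectation is for no change beyond the scatter. The expected step is a 1.0-fold lower number from compound 2 to compound 4 (0.01 log units; within the scatter). For compound 4 the estimate in this assay is 40000 nM, with a range from 15000 nM to 100000 nM; a limit rather than a number is also possible.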

Compound 4, half-maximal inhibitory concentration: > 100000 nM
Compound 4: a limit, no number; the forecaster's own chance of this, stated with the estimate: 25%; middle value at least 2.5-fold (0.39 log units) from the limit.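

This position is not neutral in this assay: 2,4-difluorophenyl in place of phenyl on the aromatic carbon of the five-membered ring gives an at least 2.4-fold higher number from compound 2 to compound 4 (0.38 log units; beyond the scatter). Among the steps shown, this is the only one beyond the scatter, whereas the acetyl change on the oxygen stayed within it, so the aromatic ring attached to the five-membered ring is the part of the molecule where a single change has so far moved the read-out, towards weaker inhibition. Compound 4 returns a limit and not a number, so only a lower bound on the step can be read, and the series now holds a second value of this kind: the limit of > 100000 nM in this assay, at which 2 of the 4 values shown sit.

From the compounds shown here alone, it remains open whether the step belongs to the two fluorine atoms together, to a single fluorine, or to any substituent on this phenyl, and a methoxy group or an amine on that ring would help separate these cases. Also unsettled is whether 2,4-difluorophenyl would act in the same direction on compound 1, which carries hydrogen in place of acetyl on the oxygen.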